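The source may report more compounds than this note shows. Statements on the series, on what has been measured and on what is new or still open speak of the compounds shown alone.

Measured so far in a functional assay on the whole organism (artery) for inhibition, with Rattus norvegicus as the target, at a dose of 3 mg/kg by the intraduodenal route; a lower number here means less inhibition, a higher number more inhibition at the dose given (going by the name of the read-out):
compound 1, `CCCCc1ccc(CN(C)S(=O)(=O)c2ccccc2)c(=O)n1Cc1ccc(-c2ccccc2-c2nn[nH]n2)cc1`, gives 68.7%
compound 2, `CCCCc1ccc(CNC(=O)Nc2ccccc2)c(=O)n1Cc1ccc(-c2ccccc2-c2nn[nH]n2)cc1`, gives 0%
compound 3, `CCCCNC(=O)NCc1ccc(CCCC)n(Cc2ccc(-c3ccccc3-c3nn[nH]n3)cc2)c1=O`, gives 10.3%

Compound 3 stands second highest of these three numbers in this assay. Its nearest neighbour is compound 2, a modest way below it, and the furthest is compound 1, far above it. All three share one core and differ only in the group on a saturated chain carbon bound to an aromatic carbon. Going from that sulfonamide to a phenylurea gave a number 68.7 percentage points lower from compound 1 to compound 2 (beyond the scatter), to a butylurea gave a number 58.4 percentage points lower from compound 1 to compound 3 (beyond the scatter), and swapping the phenyl of the urea for butyl gave a number 10.3 percentage points higher from compound 2 to compound 3 (beyond the scatter).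

Compound 4, `CCCCc1ccc(CNC(C)=O)c(=O)n1Cc1ccc(-c2ccccc2-c2nn[nH]n2)cc1`, is not yet measured in this assay. It differs from compound 3 in one place: methyl in place of butylamino on a carbonyl carbon. For the measured compounds named here, no measured step cuts a urea down to an acetamide, so none bears on it directly; what the measured steps show is that both urea-bearing compounds, compound 2 and compound 3, sit low, while only the sulfonamide of compound 1 sits high. Compound 4 keeps an amide-type nitrogen rather than returning to a sulfonamide, so a small step is expected, within the scatter, a number 2.3 percentage points lower from compound 3 to compound 4 (within the scatter). The estimate for compound 4 is 8%, with a range from 0% to 25%.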

Compound 4, a percentage reported as inhibition, in the whole organism at one dose (the size of the read-out at that dose, not a potency): 8.6%
Beside the measured number, compound 4's estimate is 0.6 percentage points below it; the measured number falls inside the stated range.
By their numbers in this assay, from the lowest: compounds 2, 4 and 3 (each within the scatter of the next, the first and the last beyond it); then compound 1.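

Cutting the urea down to an acetamido group barely registers in this assay, whether the group lost from the carbonyl carbon is butylamino (a number 1.7 percentage points lower from compound 3 to compound 4 (within the scatter)) or anilino (a number 8.6 percentage points higher from compound 2 to compound 4 (within the scatter)), so among these three compounds neither the butyl nor the phenyl of a urea sets the result apart. The contrast with the sulfonamide now also holds for a much smaller group, with acetamido in place of methyl(phenylsulfonyl)amino on the same chain carbon (a number 60.1 percentage points lower from compound 1 to compound 4 (beyond the scatter)), and among the four compounds shown, compound 1 alone sits high while the urea and acetamido compounds sit low together. Nothing measured here explains this gap.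

On these data alone, what remains open is which part of the methyl(phenylsulfonyl)amino group goes with the high number; a phenylsulfonylamino group, with hydrogen in place of the methyl, or a methylsulfonylamino group, with methyl in place of the phenyl, would help separate those parts. Also open, as far as these compounds go, is how a simple amine or a carboxylic acid on that saturated chain carbon would read in this assay.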